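Shortening the chain on the core nitrogen: propyl to methyl

The source may hold more compounds than are shown below. What is called first, only, known or untested is meant among the compounds shown, and "the series" means these compounds.

Compound 1, `CCCn1ncnc1-c1ccccc1NCC1=NCCN1`, is one of three compounds tested in a functional assay with Alpha-1B adrenergic receptor (Homo sapiens) as the target, read by calcium flux (on this read-out higher numbers stand for larger maximal responses and lower numbers for smaller maximal responses), and compound 1 gives 74%. Within this small set compound 1 stands second highest. Compound 2, `CCn1ncnc1-c1ccccc1NCC1=NCCN1`, reaches 94%, and the step of a number 20 percentage points higher from compound 1 to compound 2 (beyond the scatter) comes from a single change, hydrogen in place of methyl on a saturated chain carbon, two bonds along the chain from an aromatic nitrogen, so that ethyl replaces propyl. For the measured compounds named here, compound 3, `Cn1ccc(-c2ccccc2NCC2=NCCN2)n1`, has a different core and gives only 33%; no single-point step links compound 3 to compound 1.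

The unmeasured compound 4, `Cn1ncnc1-c1ccccc1NCC1=NCCN1`, differs from compound 1 by hydrogen in place of ethyl on a saturated chain carbon bound to an aromatic nitrogen. This continues the same shortening of the chain seen between compound 1 and compound 2, one carbon further. Going by the values given here, the only step that bears on it is the one from compound 1 to compound 2, where shortening by one carbon raised the maximal response by a modest amount beyond the scatter. Compound 3 carries a methyl too, but on another core, so its low number cannot be read as a guide here.

The step of a number 16 percentage points higher from compound 1 to compound 4 (beyond the scatter) is therefore expected to be upward, comparable in size to the step seen from compound 1 to compound 2, because of a number 20 percentage points higher from compound 1 to compound 2 (beyond the scatter). For compound 4 the estimated maximal response in this assay is 90%, expected to lie between 70% and 105%.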

Compound 4, largest response reached (reported as maximal response), in percent of the reference or control that the assay uses: 93%
Estimate against measurement, compound 4: 3 percentage points below; the range from low to high includes it.
By their numbers in this assay, from the lowest: compound 3; then compound 1; then compounds 4 and 2 (each within the scatter of the next).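

The result shows that the response at this position does not keep rising as the chain gets shorter. Replacing propyl with methyl on the saturated chain carbon bound to an aromatic nitrogen gives a modest gain (a number 19 percentage points higher from compound 1 to compound 4 (beyond the scatter)), but ethyl and methyl cannot be told apart in this assay (a number 1 percentage points lower from compound 2 to compound 4 (within the scatter)), so among these three chains only propyl stands apart. With the methyl kept, the swap of 1-methyl-1H-1,2,4-triazol-5-yl for 1-methyl-1H-pyrazol-3-yl gives a large difference (a number 60 percentage points higher from compound 3 to compound 4 (beyond the scatter)), far larger than any chain change here, although no data shown explain either effect.

Still open, from the compounds shown here alone, is whether a longer chain such as butyl would lower the response further, and whether a branched group such as isopropyl or a ring such as cyclopropyl would behave like ethyl and methyl or like propyl. For the compounds shown here, the chain trend is also seen only with the 1,2,4-triazole group, so it remains unknown whether ethyl or propyl in place of methyl would change the response in the same way on the pyrazole group of compound 3.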